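Carbamoyl addition on two related benzofuran cores

A few compounds are considered here, and "the series" means these few. Any claim that something is new, unique, unknown or untested is made for them only; others in the source may bear on it.

Measured so far in a functional assay on NSCLC-N6 cells (Homo sapiens) for cytotoxicity, read by MTT assay; on this read-out higher numbers stand for weaker inhibition and lower numbers for stronger inhibition:
Compound 1 `CCOC(=O)c1oc2cc(OCc3ccccc3)cc(OCc3ccccc3)c2c1C` — the value is a limit of the assay, > 72000 nM.
Compound 2 `CCOC(=O)c1oc2cc(O)cc(O)c2c1C` — compound 2 gives 65600 nM.
Compound 3 `CCOC(=O)c1oc2c(C(N)=O)c(OCc3ccccc3)cc(OCc3ccccc3)c2c1C` — the value is a limit of the assay, < 7200 nM.

Compound 1 and compound 3 differ by a single change, (carbamoyl in place of hydrogen on an aromatic carbon), and this brought an at least 10-fold lower number from compound 1 to compound 3 (1.00 log units; beyond the scatter), as far as the limit of < 7200 nM in this assay, at which 1 of the 3 values shown sits, and the limit of > 72000 nM in this assay, at which 1 of the 3 values shown sits, allow one to say. Compound 4 `CCOC(=O)c1oc2c(C(N)=O)c(O)cc(O)c2c1C` carries the same kind of change on the core of compound 2, (carbamoyl in place of hydrogen on an aromatic carbon); here the place is ortho to a hydroxy group and para to a hydroxy group rather than ortho to a benzyloxy group and para to a benzyloxy group. How the core of compound 2 differs from that of compound 1 is not broken down here. Beside the measured step, compound 4 is expected to show a 10-fold lower number from compound 2 to compound 4 (1.00 log units; beyond the scatter), resting on compound 2 at 65600 nM and on the step of an at least 10-fold lower number from compound 1 to compound 3 (1.00 log units; beyond the scatter). Compound 4 is therefore estimated at 6500 nM, between 1500 nM and 25000 nM.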

Compound 4, half-maximal inhibitory concentration: 32900 nM
Estimate against measurement, compound 4: 5.1-fold (0.70 log units) below; measured number above the stated range.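

In this assay, placing carbamoyl on the core of compound 2 gave a 2.0-fold lower number from compound 2 to compound 4 (0.30 log units; within the scatter), so the change did not carry over at the size seen on the core of compound 1: the same change on two cores in this assay, an at least 10-fold lower number (1.00 log units; beyond the scatter) from compound 1 to compound 3 and a 2.0-fold lower number (0.30 log units; within the scatter) from compound 2 to compound 4, at least 5.0-fold (0.70 log units) apart, beyond the scatter of two such steps. On these data alone, the earlier step joins two limits of the assay, those of compound 1 and compound 3, and its full size stays unknown. What in the two cores sets the steps apart is not shown.

As far as these compounds go, it remains open whether a core bearing one hydroxy group and one benzyloxy group would follow compound 1 or compound 2. Also open, from the compounds shown here alone, is how an amine or a carboxylic acid on the same aromatic carbon would compare with carbamoyl on either core.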